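This account rests on a few compounds, and the source may have more. Where it says the series, first, only, none or still open, it means among the compounds named here.

Within the data shown here, in a functional assay on NFS-60 cells (Mus musculus) for inhibition, with a stated time of 72 h (a higher number here means a weaker inhibitor of growth, a lower number a stronger inhibitor of growth), compound 1 `Nc1ncnc2c(C(=O)Nc3cccc4c3c(Br)nn4Cc3cccnc3)csc12` gives 77 nM, and no measured compound falls beyond the scatter below it. Compound 2 `Nc1ncnc2c(C(=O)Nc3cccc4c3c(Br)nn4Cc3ccncc3)csc12` gives 135 nM, and compound 3 `Nc1ncnc2c(C(=O)Nc3cccc4c3c(Br)nn4Cc3cccc(Br)n3)csc12` gives 243 nM. Compound 4 `Nc1ncnc2c(C(=O)Nc3cccc4c3c(Br)nn4CC3CCCCC3)csc12` carries cyclohexyl in place of pyridin-3-yl on a saturated chain carbon bound to an aromatic nitrogen. The nearest evidence comes from two exchanges at that place, a 1.8-fold higher number from compound 1 to compound 2 (0.24 log units; within the scatter) and a 3.2-fold higher number from compound 1 to compound 3 (0.50 log units; beyond the scatter). Neither brings in a non-aromatic ring, so they guide the size of the step only loosely. A modest move towards a higher number is therefore expected, and the estimated change is a 2.2-fold higher number from compound 1 to compound 4 (0.34 log units; beyond the scatter). Compound 4 is expected at 170 nM, within an estimated range of 60 nM to 500 nM.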

Compound 4, concentration for 50% growth inhibition: 254 nM
Beside the measured number, compound 4's estimate is 1.5-fold (0.17 log units) below it, within the range that was stated.
By their numbers in this assay, from the lowest: compounds 1, 2, 3 and 4 (each within the scatter of the next, the first and the last beyond it).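

In this assay, the all-carbon cyclohexyl ring, which has no hydrogen-bond acceptor, separates clearly only from pyridin-3-yl, with a 3.3-fold higher number from compound 1 to compound 4 (0.52 log units; beyond the scatter). The other two exchanges give a 1.9-fold higher number from compound 2 to compound 4 (0.27 log units; within the scatter) and a 1.0-fold higher number from compound 3 to compound 4 (0.02 log units; within the scatter), so at this place compound 4 cannot be told apart from compound 2 or compound 3. No measurement at hand explains this pattern.

As far as these compounds go, it remains open whether a piperidine ring, or a cyclohexyl ring carrying an amine, would return to the level of compound 1. From the compounds shown here alone, the effect of a longer chain between the aromatic nitrogen and the ring is also open.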